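The source may hold more compounds than are shown below. What is called first, only, known or untested is meant among the compounds shown, and "the series" means these compounds.

Compound 1 `C[C@H](c1ccc(-c2cc(Cl)ccc2-c2nc(=O)o[nH]2)cc1)N(CC1CC1)c1nc2c(C(=O)O)cccc2o1` stands lowest of the three compounds measured in an ADME assay on the whole organism (Macaca fascicularis) for pharmacokinetics, read by LC-MS, using cassette dosing, at a dose of 1 mg/kg by the oral route (on this read-out higher numbers stand for higher exposure at the dose given and lower numbers for lower exposure), where compound 1 gives 1300 ng.h/mL. Its closest neighbour is compound 3 `Cc1ccc(-c2nc(=O)o[nH]2)c(-c2ccc([C@@H](C)N(CC3CC3)c3nc4c(C(=O)O)cccc4o3)cc2)c1`, which in this assay gives 4830 ng.h/mL, and the furthest is compound 2 `C[C@H](c1ccc(-c2ccccc2-c2nc(=O)o[nH]2)cc1)N(CC1CC1)c1nc2c(C(=O)O)cccc2o1`, which gives 11600 ng.h/mL. The measured steps are an 8.9-fold higher number from compound 1 to compound 2 (0.95 log units; beyond the scatter), a 3.7-fold higher number from compound 1 to compound 3 (0.57 log units; beyond the scatter) and a 2.4-fold lower number from compound 2 to compound 3 (0.38 log units; beyond the scatter); all three are changes of a substituent on an aromatic carbon.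

Compound 4 `CCCCN(c1nc2c(C(=O)O)cccc2o1)[C@H](C)c1ccc(-c2cc(Cl)ccc2-c2nc(=O)o[nH]2)cc1` differs from compound 1 in another place: propyl in place of cyclopropyl on a saturated chain carbon bound to a nitrogen on an aromatic ring. Among the measured compounds shown here, none of the measured steps touches that chain carbon, so none of them bears directly on this change; they only show that single changes of this size have moved the number by modest amounts. For the measured compounds named here, with no measured step at this position, the most defensible expectation is a number close to that of compound 1, allowing for a step of modest size in either direction. The expected step is estimated as no change at the digits printed from compound 1 to compound 4 (within the scatter). Compound 4 is therefore expected to give about 1300 ng.h/mL, within a range from 450 ng.h/mL to 3800 ng.h/mL.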

Compound 4, area under the concentration-time curve: 1040 ng.h/mL
Estimate against measurement, compound 4: 1.3-fold (0.10 log units) above; low and high end bracket the measured number.
By their numbers in this assay, from the lowest: compounds 4 and 1 (each within the scatter of the next); then compound 3; then compound 2.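

In this assay, among the compounds shown here, the first measured change at this chain carbon, propyl in place of cyclopropyl, gives a 1.3-fold lower number from compound 1 to compound 4 (0.10 log units; within the scatter), so opening the three-membered ring while keeping the same count of heavy atoms leaves the two compounds indistinguishable on this read-out. For the compounds shown here, this sets the position apart from the chloro site, where a single substituent change gives an 8.9-fold higher number from compound 1 to compound 2 (0.95 log units; beyond the scatter) and another gives a 3.7-fold higher number from compound 1 to compound 3 (0.57 log units; beyond the scatter); within these compounds, the chloro site is the one where a single change has shifted the number beyond the scatter. No measured evidence is available to explain this result.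

Going by these compounds, both compound 1 and compound 4 carry the chloro group, so it remains open whether the same swap would also stay within the scatter on the hydrogen of compound 2 or the methyl of compound 3, where the numbers are much higher. Also open, on these data alone, is whether a longer chain, a cyclobutyl ring or a chain holding an ether oxygen at this chain carbon would stay as close to compound 1 as propyl does.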